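Trimethoxyphenyl pyrazolyl chalcones: one methoxy step repeated

A few compounds are considered here, and "the series" means these few. Any claim that something is new, unique, unknown or untested is made for them only; others in the source may bear on it.

Compound 1, `COc1cc(-c2cc(/C=C/C(=O)c3ccc(N)cc3)[nH]n2)cc(OC)c1OC`, 1350 nM
Compound 2, `COc1ccc(C(=O)/C=C/c2cc(-c3cc(OC)c(OC)c(OC)c3)n[nH]2)cc1OC`, 1350 nM
Compound 3, `COc1ccc(-c2cc(/C=C/C(=O)c3ccc(N)cc3)[nH]n2)cc1OC`, 2150 nM

Three compounds were measured in a functional assay on RXF 393 cells (Homo sapiens) for inhibition, read by sulforhodamine B assay, with a stated time of 48 h; on this read-out higher numbers stand for weaker inhibition of growth and lower numbers for stronger inhibition of growth. Compound 1 gives 1350 nM, compound 2 gives 1350 nM, and compound 3 gives 2150 nM. The change from compound 3 to compound 1 is methoxy in place of hydrogen on an aromatic carbon, and in this assay it brought a 1.6-fold lower number from compound 3 to compound 1 (0.20 log units; within the scatter). Compound 2 and compound 1 differ by no change at the digits printed from compound 1 to compound 2 (within the scatter). The difference between the core of compound 2 and the core of compound 3 is not broken down here.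

Compound 4, `COc1cc(C(=O)/C=C/c2cc(-c3cc(OC)c(OC)c(OC)c3)n[nH]2)cc(OC)c1OC`, is not yet measured. It differs from compound 2 by methoxy in place of hydrogen on an aromatic carbon, the same kind of change as that from compound 3 to compound 1, with the place described in the same words. The step is expected to resemble a 1.6-fold lower number from compound 3 to compound 1 (0.20 log units; within the scatter), so from compound 2 the expected step is a 1.5-fold lower number from compound 2 to compound 4 (0.18 log units; within the scatter), because compound 2 gives 1350 nM. Compound 4 is therefore estimated at 900 nM, with a likely range from 400 nM to 2000 nM.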

Compound 4, concentration for 50% growth inhibition: 1260 nM
Compound 4: the middle estimate sits 1.4-fold (0.15 log units) below what was measured, and the stated range covers the measured number.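

In this assay, methoxy in place of hydrogen on an aromatic carbon gave a 1.1-fold lower number from compound 2 to compound 4 (0.03 log units; within the scatter). The two cases of this change agree: the same change on two cores in this assay, a 1.6-fold lower number (0.20 log units; within the scatter) from compound 3 to compound 1 and a 1.1-fold lower number (0.03 log units; within the scatter) from compound 2 to compound 4, 1.5-fold (0.17 log units) apart, within the scatter of two such steps. As far as this read-out can tell, the change carries from one core to the other, but each step lies within the scatter, so neither shows that methoxy alters growth inhibition on its core, and two cases set no rule for the series.

The compounds shown leave open what a carboxylic acid or a longer chain such as butoxy would do on the same aromatic carbon. They also leave open whether the two steps would stay alike in other cell lines.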